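This account rests on a few compounds, and the source may have more. Where it says the series, first, only, none or still open, it means among the compounds named here.

Measured compounds:
Compound 1, `CCc1ccc(-c2cc(Cl)cc(C(=O)Nc3nn[nH]n3)n2)cc1`, gives 100%.
Compound 2, `CCOc1cc(C(=O)Nc2nn[nH]n2)nc(-c2ccc(N)cc2)c1`, gives 62%.

Both numbers come from a functional assay on the whole organism with Rattus norvegicus as the target, at a dose of 3 mg/kg by the oral route (a lower number here means a weaker effect, a higher number a stronger effect of the compound at the dose given), where every value reported at a single dose tells how strong or weak the effect of the compound is at that dose. Compound 2 stands lowest of the two numbers shown, and its nearest neighbour is compound 1, whose number lies higher by a margin that is beyond the usual scatter of such measurements. Among the measured compounds shown here, the two compounds differ in more than one place, so no single structural step between them is traced here.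

The step under study leads from compound 2 to compound 3, `Cc1cc(C(=O)Nc2nn[nH]n2)nc(-c2ccc(N)cc2)c1`, which has not yet been measured in this assay. The change is methyl in place of ethoxy on an aromatic carbon, on the shared core, at the position described there: meta to the (2H-tetrazol-5-yl)carbamoyl group, meta to the 4-aminophenyl group, and opposite the ring nitrogen.

For the measured compounds named here, no measured pair shows what this exact exchange does, so the expectation rests on compound 2 alone. The step from compound 2 to compound 3 is expected to stay within the scatter, as a number 2 percentage points lower from compound 2 to compound 3 (within the scatter). Compound 3 is therefore estimated at 60%, with a range from 35% to 85%.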

Compound 3, a percentage reported as inhibition, in the whole organism at one dose (the size of the read-out at that dose, not a potency): 100%
For compound 3 the middle estimate is 40 percentage points below the measured one; the measured number lies above the stated range.
By their numbers in this assay, from the lowest: compound 2; then compounds 1 and 3 (each within the scatter of the next).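

In this assay, exchanging ethoxy for methyl gives a number 38 percentage points higher from compound 2 to compound 3 (beyond the scatter) at the position meta to the (2H-tetrazol-5-yl)carbamoyl group, meta to the 4-aminophenyl group and opposite the ring nitrogen. This is the first pair shown that differs in only one place, and it reveals that the group at this position can strongly alter the effect of the compound at this oral dose, with the rest of the structure unchanged. No measured property of these compounds offers an explanation for the step.

The compounds shown leave open whether the oxygen of ethoxy or the length of its chain matters more, a question that a methoxy group, which keeps the oxygen on a shorter chain, and a propyl chain, which has no oxygen, could help to separate. Also open, going by these compounds, is whether the step would persist at other doses, as this read-out describes the size of the effect at one dose and is not a potency.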